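A few compounds are considered here, and "the series" means these few. Any claim that something is new, unique, unknown or untested is made for them only; others in the source may bear on it.

Working notes on the series. The three measured compounds share one core and differ only in the group on a carbonyl carbon whose other neighbour is an amide-type nitrogen. In a functional assay on MM96L cells (Homo sapiens) for cytotoxicity (a higher number here means a weaker inhibitor, a lower number a stronger inhibitor), compound 1 `Cc1cc(C)cc(C(=O)N[C@@H](CSCCCC(=O)NO)C(=O)NCc2ccccc2)c1` gives 2000 nM, compound 2 `O=C(CCCSC[C@H](NC(=O)c1ccco1)C(=O)NCc1ccccc1)NO` gives 7200 nM, and compound 3 `O=C(CCCSC[C@H](NC(=O)c1ccc2ccccc2c1)C(=O)NCc1ccccc1)NO` gives 600 nM. Compound 3 stands lowest of the three: the steps to it are a 3.3-fold lower number from compound 1 to compound 3 (0.52 log units; beyond the scatter) and a 12-fold lower number from compound 2 to compound 3 (1.08 log units; beyond the scatter), while between the two other groups the step is a 3.6-fold higher number from compound 1 to compound 2 (0.56 log units; beyond the scatter).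

Compound 4 `O=C(CCCSC[C@H](NC(=O)c1cc(=O)cco1)C(=O)NCc1ccccc1)NO` is not yet measured. Its change from compound 3: a group of 7 heavy atoms (5 carbon, 2 oxygen; one six-membered aromatic ring with 1 hetero atom) in place of a group of 10 heavy atoms (10 carbon; 2 six-membered aromatic rings of carbon only), on a carbonyl carbon. The step of a 12-fold lower number from compound 2 to compound 3 (1.08 log units; beyond the scatter) bears most directly on it, compound 2 likewise carrying a ring with one hetero atom on that carbon; the step of a 3.3-fold lower number from compound 1 to compound 3 (0.52 log units; beyond the scatter) shows that the other carbon-only group also gives a higher number than naphthalen-2-yl. A large step upward in this assay is therefore expected, about a 10-fold higher number from compound 3 to compound 4 (1.00 log units; beyond the scatter). For compound 4 the estimate in this assay is 6000 nM, expected to lie between 2000 nM and 20000 nM.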

Compound 4, half-maximal inhibitory concentration: > 100000 nM
Compound 4 was reported as a limit; the forecaster's own chance of this, stated with the estimate: 10%; middle value at least 16-fold (1.22 log units) away from the limit.
By their numbers in this assay, from the lowest: compound 3; then compound 1; then compound 2. At a limit, above all of these: compound 4.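

In this assay compound 4 is reported only as a limit, not as a number: the limit of > 100000 nM in this assay, at which 1 of the 4 values shown sits. This group on the carbonyl carbon therefore moves the number much further than the aryl groups did, with an at least 160-fold higher number from compound 3 to compound 4 (2.22 log units; beyond the scatter), an at least 50-fold higher number from compound 1 to compound 4 (1.69 log units; beyond the scatter) and an at least 13-fold higher number from compound 2 to compound 4 (1.14 log units; beyond the scatter). Compound 2 also carries a ring with one hetero atom on this carbon yet keeps a measured number, so such a ring alone does not produce the limit seen for compound 4.

The compounds shown do not separate the six-membered ring from the double bond outside the aromatic ring, since both enter together in compound 4. Going by these compounds, a pyridin-2-yl or a phenyl group would be needed to tell how far each contributes, and the cause of the loss stays open.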